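The source may hold more compounds than are shown below. What is called first, only, known or untested is meant among the compounds shown, and "the series" means these compounds.

In a functional assay on MDA-MB-231 cells (Homo sapiens) for cytotoxicity, read by ELISA, with a stated time of 2 days (a higher number here means a weaker inhibitor, a lower number a stronger inhibitor), compound 1 (`Oc1ccc(-c2cc(-c3ccccc3)cc(-c3cccs3)n2)cc1`) gives 2400 nM, compound 2 (`Oc1ccc(-c2cc(-c3ccccc3)cc(-c3cccnc3)n2)cc1`) gives 2200 nM and compound 3 (`Oc1cccc(-c2cc(-c3ccccc3)nc(-c3cccs3)c2)c1`) gives 17700 nM. Compound 3 therefore has the highest number of the three, which makes it the weakest inhibitor so far. Compound 4 (`Oc1cccc(-c2cc(-c3ccccc3)nc(-c3cccnc3)c2)c1`) differs from compound 3 in one place, with pyridin-3-yl in place of thiophen-2-yl on an aromatic carbon, next to the ring nitrogen: pyridin-3-yl in place of thiophen-2-yl on an aromatic carbon. Going by the values given here, one measured step bears on this. The same swap has been made once before, and it gave a 1.1-fold lower number from compound 1 to compound 2 (0.04 log units; within the scatter). That step is small, but it comes from a different core, so it is only a guide for compound 3, whose own core carries the hydroxyl group differently. On this evidence, no step beyond the scatter is expected in this assay. The expected step is a 1.1-fold lower number from compound 3 to compound 4 (0.04 log units; within the scatter). For compound 4 the estimated value is 16000 nM, with an expected range from 8000 nM to 32000 nM.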

Compound 4, half-maximal inhibitory concentration: 22800 nM
Compound 4: middle estimate off by 1.4-fold (0.15 log units), on the low side; the measured number falls inside the stated range.
By their numbers in this assay, from the lowest: compounds 2 and 1 (each within the scatter of the next); then compounds 3 and 4 (each within the scatter of the next).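

In this assay, placing pyridin-3-yl in place of thiophen-2-yl on this aromatic carbon, next to the ring nitrogen, gives a 1.3-fold higher number from compound 3 to compound 4 (0.11 log units; within the scatter), so the two rings cannot be told apart at this position. The earlier pair showed this on one core only, and the outcome now holds on a second core that carries a 3-hydroxyphenyl group: the same change on two cores in this assay, a 1.1-fold lower number (0.04 log units; within the scatter) from compound 1 to compound 2 and a 1.3-fold higher number (0.11 log units; within the scatter) from compound 3 to compound 4, 1.4-fold (0.15 log units) apart, within the scatter of two such steps Across these four compounds, then, a five-membered and a six-membered aromatic ring, each with one hetero atom, serve equally well in this swap.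

The compounds shown place only these two aromatic rings here, so what an amine, a carboxylic acid or a longer chain would do at this position remains open. Compound 1 and compound 3 differ in more than one place, which leaves unsettled which difference between the two cores sets their numbers apart.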